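The compounds below may be only part of what the source reports. "The series", "measured", "known", "first", "only" and "open" are said of these compounds alone.

Measured so far in a functional assay on K562 cells (Homo sapiens) for cytotoxicity, read by ELISA, with a stated time of 4 days; on this read-out higher numbers stand for weaker inhibition and lower numbers for stronger inhibition:
- compound 1 `Cc1ccsc1-c1cc(-c2ccoc2)cc(-c2ccc(Cl)cc2)n1`: 19600 nM
- compound 2 `Cc1ccc(-c2cc(-c3ccoc3)cc(-c3ccc(Cl)s3)n2)o1`: 12700 nM
- compound 3 `Cc1ccccc1-c1cc(-c2ccoc2)cc(-c2ccc(Cl)s2)n1`: 12300 nM

Compound 1 has the highest of the three numbers, but its gap to compound 2 and to compound 3 lies within the scatter, so the three measured compounds are not separable on this read-out. Going by the values given here, the only single-point step among them, a 1.0-fold lower number from compound 2 to compound 3 (0.01 log units; within the scatter), is also within the scatter: swapping one aryl group for another at the carbon next to the ring nitrogen of the shared core left the number essentially where it was.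

Compound 4 `Clc1ccc(-c2cc(-c3ccoc3)cc(-c3ccc(Cl)s3)n2)cc1` is the next compound for this assay. It differs from compound 1 by 5-chlorothiophen-2-yl in place of 3-methylthiophen-2-yl on an aromatic carbon. Among the compounds with values here, the exchanged group sits at the same kind of position as the one varied between compound 2 and compound 3, and that step was flat. Compound 2 and compound 3 already carry the 5-chlorothiophen-2-yl group that enters here, and their values sit close to compound 1. Within the data shown here, no step bearing on the 4-chlorophenyl side is available.

The expectation for compound 4 is therefore a step of a 1.4-fold lower number from compound 1 to compound 4 (0.15 log units; within the scatter), nothing beyond the scatter. Compound 4 is estimated at 14000 nM, with a range from 5000 nM to 40000 nM.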

Compound 4, half-maximal inhibitory concentration: 19600 nM
The estimate for compound 4 lay 1.4-fold (0.15 log units) below the measured number; the range from low to high includes it.
By their numbers in this assay, from the lowest: compounds 3, 2, 1 and 4 (each within the scatter of the next).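

In this assay, placing 5-chlorothiophen-2-yl instead of 3-methylthiophen-2-yl on the aromatic carbon next to the ring nitrogen gives no change at the digits printed from compound 1 to compound 4 (within the scatter) and so leaves the number unmoved with 4-chlorophenyl and furan-3-yl held in place. With 5-chlorothiophen-2-yl held in place, the exchanges to 4-chlorophenyl give a 1.6-fold higher number from compound 3 to compound 4 (0.20 log units; within the scatter) from 2-methylphenyl and a 1.5-fold higher number from compound 2 to compound 4 (0.19 log units; within the scatter) from 5-methylfuran-2-yl, so neither exchange separates these compounds on this read-out. No measurement at hand offers an explanation for these flat steps.

Every group shown at these aromatic carbons is an aromatic ring, so the compounds cannot say whether an amine, a carboxylic acid or a longer chain there would shift the number beyond the scatter. The furan-3-yl group is common to all four compounds, which leaves its contribution to the number unread.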